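Swapping the Benzyl Group on a Weak Dithiocarbamate Amide

The source may hold more compounds than are shown below. What is called first, only, known or untested is meant among the compounds shown, and "the series" means these compounds.

Measured compounds:
compound 1, `COc1ccc(CN(C(=O)CSC(=S)N2CCc3cc(Br)ccc32)c2cc(OC)c(OC)c(OC)c2)cc1`, > 20000 nM
compound 2, `COc1cc(N(Cc2ccc(Cl)cc2)C(=O)CSC(=S)N2CCN(C(=O)OC(C)(C)C)CC2)cc(OC)c1OC`, 11900 nM

Among the compounds with values here, in a functional assay on KYSE-450 cells (Homo sapiens) for inhibition, read by CCK-8 assay, with a stated time of 48 h (a lower number here means a stronger inhibitor, a higher number a weaker inhibitor), compound 2 gives 11900 nM, the only number recorded. For compound 1 the result is a limit of the assay, > 20000 nM, as noted in the limit of > 20000 nM in this assay, at which 1 of the 2 values shown sits. Compound 3, `COc1ccc(CN(C(=O)CSC(=S)N2CCN(C(=O)OC(C)(C)C)CC2)c2cc(OC)c(OC)c(OC)c2)cc1Br`, has not yet been measured; it differs from compound 2 by 3-bromo-4-methoxyphenyl in place of 4-chlorophenyl on a saturated chain carbon bound to an amide-type nitrogen. No measured step of this kind exists among the compounds shown, so the change is expected to be small, at most a shift toward weaker inhibition, a 1.3-fold higher number from compound 2 to compound 3 (0.13 log units; within the scatter). Compound 3 is therefore expected to give about 16000 nM, between 5000 nM and 40000 nM.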

Compound 3, half-maximal inhibitory concentration: 1850 nM
Estimate against measurement, compound 3: 8.6-fold (0.94 log units) above; measured number outside the range, below it.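

In this assay, the group on the saturated chain carbon bound to an amide-type nitrogen clearly matters: 3-bromo-4-methoxyphenyl in place of 4-chlorophenyl gives a 6.4-fold lower number from compound 2 to compound 3 (0.81 log units; beyond the scatter). Within the data shown here, this is the first step that can be read at this place, and it lies beyond the scatter. Nothing measured here accounts for the gain.

The change replaces the chlorine and adds both bromine and methoxy, so the compounds shown do not separate their contributions. On these data alone, how a plain 3-bromophenyl group or a dimethylaminophenyl group would read at this place remains open.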